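Adding Hydroxymethyl to the Phenyl of Compound 2

A few compounds are considered here, and "the series" means these few. Any claim that something is new, unique, unknown or untested is made for them only; others in the source may bear on it.

Among the compounds with values here, compound 2 `Nc1nc(-c2ccccc2)nc2sc(-c3ccco3)nc12` is one of two compounds measured so far in an assay on CHO cells for displacement of a labelled ligand from adenosine receptor A1 (Homo sapiens), read by scintillation counting, with a stated time of 3 h; on this read-out higher numbers stand for weaker inhibition and lower numbers for stronger inhibition. In this assay compound 2 gives 33 nM, the lower of the two numbers. Compound 1 `Nc1nc(-c2ccc(CO)cc2)nc2sc(-c3ccccc3)nc12` gives 82 nM in this assay, a number higher than that of compound 2 by a margin beyond the scatter. Compound 1, however, differs from compound 2 in two places at once, so these two values alone cannot say how much each place contributes.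

Compound 3 `Nc1nc(-c2ccc(CO)cc2)nc2sc(-c3ccco3)nc12` has not yet been measured in this assay. It differs from compound 2 by a single change: hydroxymethyl in place of hydrogen on an aromatic carbon. Within the data shown here, no measured pair differs in only this way, so the size of the step has to be estimated. The expected step is a 1.4-fold higher number from compound 2 to compound 3 (0.13 log units; within the scatter), leaning toward a weaker result, but not clearly beyond the usual scatter. Compound 3 is therefore estimated to give 45 nM in this assay, with a range from 15 nM to 140 nM.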

Compound 3, inhibition constant: 77.7 nM
Estimate against measurement, compound 3: 1.7-fold (0.24 log units) below; measured number inside the range.
By their numbers in this assay, from the lowest: compound 2; then compounds 3 and 1 (each within the scatter of the next).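

In this assay, hydroxymethyl in place of hydrogen on an aromatic carbon, para to a large group, can now be read as a single change: with furan-2-yl kept in place, it gives a 2.4-fold higher number from compound 2 to compound 3 (0.37 log units; beyond the scatter), a modest step toward weaker inhibition that lies beyond the scatter. The other single change, furan-2-yl in place of phenyl with hydroxymethyl kept in place, gives a 1.1-fold lower number from compound 1 to compound 3 (0.02 log units; within the scatter), so when hydroxymethyl is present, these two groups cannot be told apart on this read-out. No measurement available here accounts for the size of either step.

As far as these compounds go, the comparison between furan-2-yl and phenyl rests on compounds that carry hydroxymethyl, so it remains open whether the two groups would also match with hydrogen in that place. From the compounds shown here alone, it is also open whether the modest step belongs to hydroxymethyl in particular or would also appear with another group in the same place, such as an amine, a carboxylic acid or a longer chain ending in a hydroxyl group.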